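Replacing the Methylpyrazinyl Amide with a Thiadiazolyl Amide

A few compounds are considered here, and "the series" means these few. Any claim that something is new, unique, unknown or untested is made for them only; others in the source may bear on it.

Of the compounds shown here, three built on one shared core have been measured in an assay on HEK293 cells for agonist activity at Toll-like receptor 8 (Homo sapiens), read by a luciferase reporter, with a stated time of 6 h; a lower number here means that less compound is needed, a higher number that more compound is needed for the effect. Compound 1 `CCCCNc1nc(N)nc2c1CN(C(=O)c1ccccc1)CC2` gives 1.4 uM. Compound 2 `CCCCNc1nc(N)nc2c1CN(C(=O)c1cnccn1)CC2` gives 2.2 uM, and compound 3 `CCCCNc1nc(N)nc2c1CN(C(=O)c1cnc(C)cn1)CC2` gives 6.8 uM. On these numbers compound 3 stands highest: compound 2 is its nearest neighbour, and compound 1 lies furthest from it. The step of a 1.6-fold higher number from compound 1 to compound 2 (0.20 log units; within the scatter) stays within the scatter, whereas a 4.9-fold higher number from compound 1 to compound 3 (0.69 log units; beyond the scatter) and a 3.1-fold higher number from compound 2 to compound 3 (0.49 log units; beyond the scatter) both go beyond it.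

Compound 4 `CCCCNc1nc(N)nc2c1CN(C(=O)c1csnn1)CC2` has not yet been measured. It differs from compound 3 in one place: 1,2,3-thiadiazol-4-yl in place of 5-methylpyrazin-2-yl on a carbonyl carbon. Among the compounds with values here, two measured steps bear on this change. The step of a 1.6-fold higher number from compound 1 to compound 2 (0.20 log units; within the scatter) shows that exchanging one aromatic ring on the carbonyl carbon for another left the number essentially where it was, while a 3.1-fold higher number from compound 2 to compound 3 (0.49 log units; beyond the scatter), in which methyl replaced hydrogen, went beyond the scatter. Compound 4 carries no methyl and again places an aromatic ring on the carbonyl carbon, so its number is expected to move back toward those of compound 1 and compound 2. Compound 4 is therefore expected to show a step of a 2.7-fold lower number from compound 3 to compound 4 (0.43 log units; beyond the scatter). In this assay compound 4 is estimated at 2.5 uM, within a range of 1 uM to 6 uM.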

Compound 4, minimum effective concentration: 0.1 uM
Estimate against measurement, compound 4: 25-fold (1.40 log units) above, outside the stated range (below it).
By their numbers in this assay, from the lowest: compound 4; then compounds 1 and 2 (each within the scatter of the next); then compound 3.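

In this assay, within the data shown here, the ring on the carbonyl carbon proves able to move the number much further than the earlier compounds showed: 1,2,3-thiadiazol-4-yl in place of 5-methylpyrazin-2-yl gives a large drop (a 68-fold lower number from compound 3 to compound 4 (1.83 log units; beyond the scatter)), and the drop remains large against pyrazin-2-yl (a 22-fold lower number from compound 2 to compound 4 (1.34 log units; beyond the scatter)) and against phenyl (a 14-fold lower number from compound 1 to compound 4 (1.15 log units; beyond the scatter)). Compound 1 and compound 2 had stayed within the scatter of each other, so exchanging one aromatic ring for another had seemed to leave this place insensitive, but compound 4 shows that this holds only for that pair and that the absence of the methyl alone does not account for its number, since compound 2 also lacks a methyl. Nothing measured here explains the gain.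

The compounds shown leave open whether the gain belongs to the five-membered ring, to its sulfur or to the particular arrangement of its hetero atoms, which thiazol-4-yl, furan-2-yl or 1,2,5-thiadiazol-3-yl on the same carbonyl carbon could separate. They also leave open whether a methyl on the 1,2,3-thiadiazol-4-yl ring would raise the number as it did on the pyrazine ring.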